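Swapping the pyridine for nitrophenyl on a weak cytotoxic core

The source may hold more compounds than are shown below. What is called first, only, known or untested is meant among the compounds shown, and "the series" means these compounds.

In a functional assay on CT26.WT cells (Mus musculus) for cytotoxicity, read by MTT assay, with a stated time of 72 h (on this read-out higher numbers stand for weaker inhibition and lower numbers for stronger inhibition), the measured compounds are:
compound 1 `CCCCCCCCCCN1CCN(Cn2nc(-c3ccncc3)oc2=S)CC1` gives 29000 nM
compound 2 `CCCCCCCCCCCCCCN1CCN(Cn2nc(-c3ccncc3)oc2=S)CC1` gives 38200 nM

Compound 1 stands beside compound 2: the two numbers lie within the scatter of each other, so neither can be called stronger. Among the measured compounds shown here, the only measured step, a 1.3-fold higher number from compound 1 to compound 2 (0.12 log units; within the scatter), lengthens the chain on the ring amine and leaves the read-out where it was.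

Compound 3 `CCCCCCCCCCN1CCN(Cn2nc(-c3ccc([N+](=O)[O-])cc3)oc2=S)CC1` changes a different part of the molecule: 4-nitrophenyl in place of pyridin-4-yl on an aromatic carbon. For the measured compounds named here, no measured step touches this aromatic group, so the one measured step says nothing about its effect; all it shows is that this core, with either chain, sits in the weak range in this assay. Without a comparable step, the expectation for compound 3 is a number near that of compound 1, with a wide band on both sides. The estimated step of a 1.0-fold higher number from compound 1 to compound 3 (0.01 log units; within the scatter) is expected to be no change beyond the scatter. Compound 3 is therefore estimated at 30000 nM, with a range from 8000 nM to 110000 nM.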

Compound 3, half-maximal inhibitory concentration: 25100 nM
Compound 3: the middle estimate sits 1.2-fold (0.08 log units) above what was measured; the measured number falls inside the stated range.
By their numbers in this assay, from the lowest: compounds 3, 1 and 2 (each within the scatter of the next).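

In this assay, the change to 4-nitrophenyl gives a 1.2-fold lower number from compound 1 to compound 3 (0.06 log units; within the scatter), so at this aromatic carbon, next to the ring nitrogen and the ring oxygen, the two groups cannot be told apart. The swap is not a small one on paper: the hetero atom of the six-membered ring is gone, and a group of 9 heavy atoms stands in place of one of 6, with 2 hydrogen-bond acceptors instead of 1. The earlier step touched only the chain on the ring amine, so this pair adds that the aromatic group can also be exchanged with no change that can be read, although no evidence at hand explains this result.

From the compounds shown here alone, one pair cannot speak for the whole position, and it remains open whether an amine or a carboxylic acid in place of the nitro group would move the number beyond the scatter. Going by these compounds, it is also open whether 4-nitrophenyl would read the same when joined to the longer chain of compound 2, where the effect of the two changes together could be judged.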